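The source may report more compounds than this note shows. Statements on the series, on what has been measured and on what is new or still open speak of the compounds shown alone.

Measured compounds:
Compound 1 `COc1cccc(C(O)CCn2nc3c(Br)c(Br)c(Br)c(Br)c3n2)c1` — 2%
Compound 2 `OC(CCn1nc2c(Br)c(Br)c(Br)c(Br)c2n1)c1ccccc1` — 0%

Both compounds were tested in a functional assay on CCRF-CEM cells (Homo sapiens) for antiproliferative activity, read by MTT assay, with a stated time of 48 h, tested at 50 uM; a higher number here means a weaker effect of the compound at the concentration tested, a lower number a stronger effect. Compound 1 gives 2% in this assay, and compound 2 gives 0%. Among the measured compounds shown here, compound 1 thus stands together with compound 2 at the strong end of the read-out, and the only measured step, a number 2 percentage points lower from compound 1 to compound 2 (within the scatter), shows that swapping hydrogen for methoxy on an aromatic carbon does not move the number beyond the scatter.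

The unmeasured compound 3 `CC(O)CCn1nc2c(Br)c(Br)c(Br)c(Br)c2n1` differs from compound 1 by methyl in place of 3-methoxyphenyl on a saturated chain carbon bound to an oxygen on a saturated carbon and a saturated chain carbon. For the measured compounds named here, no measured step removes the aromatic ring from this part of the chain, so the bearing of the one known step is indirect: it only shows that a change on that ring leaves the read-out where it is. With both measured compounds near the bottom of the scale, a step in this assay from compound 1 to compound 3 of no more than the scatter is expected, in either direction.

Compound 3 is therefore expected to give about 5% in this assay, with a range from 0% to 25%. This estimate means a step of a number 3 percentage points higher from compound 1 to compound 3 (within the scatter), expected to stay within the scatter.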

Compound 3, a percentage reported as activity, at one concentration (the size of the read-out at that concentration, not a potency): 45%
Estimate against measurement, compound 3: 40 percentage points below; measured number above the stated range.
By their numbers in this assay, from the lowest: compounds 2 and 1 (each within the scatter of the next); then compound 3.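

Among the compounds shown here, the earlier pair showed only that a change on the aromatic ring leaves the read-out in place, whereas this result shows that removing the whole ring does not. In this assay there is a number 43 percentage points higher from compound 1 to compound 3 (beyond the scatter) when methyl replaces 3-methoxyphenyl, and there is a number 45 percentage points higher from compound 2 to compound 3 (beyond the scatter) when methyl replaces phenyl, so both steps are large and both point towards a weaker effect at the concentration tested. At this place on the saturated chain, an aromatic ring, with or without methoxy, thus goes with a much stronger effect than methyl does, although the data shown give no explanation for this difference.

The compounds shown leave open whether the ring must be aromatic, which a cyclohexyl group at the same place would test, and whether smaller groups such as ethyl or isopropyl would already bring back part of the effect. As far as these compounds go, since this is a read-out at one concentration and compound 1 and compound 2 sit near the bottom of the scale, it also remains open whether methoxy on the ring makes any difference at lower concentrations.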